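Sulfonamide series: phenyl to tert-butyl on the benzyl ring

The compounds below may be only part of what the source reports. "The series", "measured", "known", "first", "only" and "open" are said of these compounds alone.

Measured so far in a functional assay on PANC-1 cells (Homo sapiens) for inhibition, read by MTT assay, with a stated time of 72 h; on this read-out higher numbers stand for weaker inhibition of growth and lower numbers for stronger inhibition of growth:
compound 1 `CC(C)(C)c1ccc(CNCCCNS(=O)(=O)c2cc(C(F)(F)F)cc(C(F)(F)F)c2)cc1`: 2500 nM
compound 2 `O=S(=O)(NCCNCc1ccc(-c2ccccc2)cc1)c1cc(C(F)(F)F)cc(C(F)(F)F)c1`: 4200 nM
compound 3 `O=S(=O)(NCCCNCc1ccc(-c2ccccc2)cc1)c1cc(C(F)(F)F)cc(C(F)(F)F)c1`: 2500 nM

Compound 2 and compound 3 share the sulfonamide and benzylamine ends but differ in the chain between them; the difference between the two cores is not broken down here. In this assay their values, and that of compound 1, all lie within the usual scatter of one another, so no order among the three can be read.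

One change is seen twice. From compound 3 to compound 1 it is tert-butyl in place of phenyl on an aromatic carbon, and the step is no change at the digits printed from compound 3 to compound 1 (within the scatter). Compound 4 `CC(C)(C)c1ccc(CNCCNS(=O)(=O)c2cc(C(F)(F)F)cc(C(F)(F)F)c2)cc1`, not yet measured, carries the same change on the core of compound 2: tert-butyl in place of phenyl on an aromatic carbon. The place is the same in both pairs.

The step from compound 2 to compound 4 is expected to be a 1.1-fold lower number from compound 2 to compound 4 (0.02 log units; within the scatter) because no change at the digits printed from compound 3 to compound 1 (within the scatter) on the other core showed none. Compound 4 is estimated at 4000 nM, between 1600 nM and 10000 nM.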

Compound 4, concentration for 50% growth inhibition: 13000 nM
The estimate for compound 4 lay 3.3-fold (0.51 log units) below the measured number, and the stated range ends below it.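

In this assay, tert-butyl in place of phenyl on an aromatic carbon gives a 3.1-fold higher number from compound 2 to compound 4 (0.49 log units; beyond the scatter), a weakening of growth inhibition on the core of compound 2. The same change does not carry over with the same size from one core to the other: the same change on two cores in this assay, no change at the digits printed (within the scatter) from compound 3 to compound 1 and a 3.1-fold higher number (0.49 log units; beyond the scatter) from compound 2 to compound 4, 3.1-fold (0.49 log units) apart, beyond the scatter of two such steps This shows that, for these two cores, the step on one did not foretell the step on the other, but it does not show what sets the two apart, and two pairs give no rule for the series.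

Still open, as far as these compounds go, is how this change behaves with a longer chain linking the sulfonamide and benzylamine ends. Also open, from the compounds shown here alone, is whether other groups at the same place, such as methoxy or chlorine, would track phenyl or tert-butyl.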